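A few compounds are considered here, and "the series" means these few. Any claim that something is new, unique, unknown or untested is made for them only; others in the source may bear on it.

Compound 1 `O=C(N/N=C/c1ccccc1)Nc1ccc(Oc2ccnc3[nH]ccc23)c(F)c1` is the reference point of this set. In a functional assay on HepG2 cells (Homo sapiens) for antiproliferative activity, read by MTT assay, with a stated time of 72 h (on this read-out lower numbers stand for stronger inhibition and higher numbers for weaker inhibition), compound 1 gives 640 nM, the lowest of the two numbers in hand. Compound 3 `O=C(N/N=C/c1ccc(O)cc1)Nc1ccc(Oc2ccnc3[nH]ccc23)c(F)c1` in this assay gives 1950 nM, and compound 2 `O=C(N/N=C/c1cccc(Cl)c1Cl)Nc1ccc(Oc2ccnc3[nH]ccc23)c(F)c1` is reported as "not active" (no number reported), without a number. Going by the values given here, the one single-place step measured, a 3.0-fold higher number from compound 1 to compound 3 (0.48 log units; beyond the scatter), weakens inhibition modestly on adding a group at the same ring position. Compound 4 `COc1ccc(/C=N/NC(=O)Nc2ccc(Oc3ccnc4[nH]ccc34)c(F)c2)cc1` differs from compound 1 by methoxy in place of hydrogen on an aromatic carbon. That change mirrors the hydroxy step in place, so a comparable move is expected, though a methoxy may sit closer to compound 1; the estimated step is a 1.7-fold higher number from compound 1 to compound 4 (0.24 log units; within the scatter). Compound 4 is therefore estimated at 1100 nM in this assay, within a range of 500 nM to 2500 nM.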

Compound 4, half-maximal inhibitory concentration: 1770 nM
Beside the measured number, compound 4's estimate is 1.6-fold (0.21 log units) below it; low and high end bracket the measured number.
By their numbers in this assay, from the lowest: compound 1; then compounds 4 and 3 (each within the scatter of the next).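

In this assay, a second group on the aromatic carbon para to a large group gives a loss that the hydroxy step alone could not establish: a 2.8-fold higher number from compound 1 to compound 4 (0.44 log units; beyond the scatter). Compound 3 and compound 4 cannot be told apart, with a 1.1-fold lower number from compound 3 to compound 4 (0.04 log units; within the scatter), so replacing the hydroxy hydrogen with methyl does not separate them. Nothing available explains this shared loss.

Going by these compounds, it remains open whether an amine, a carboxylic acid or a longer alkoxy chain at this position would read like compound 1 or like compound 3 and compound 4.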